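A few compounds are considered here, and "the series" means these few. Any claim that something is new, unique, unknown or untested is made for them only; others in the source may bear on it.

Compound 1 `CO[C@@H]1CN(CC2Cc3ccccc3C2)CC[C@H]1n1c(C)nc2cc(C)ccc21`: a functional assay for antagonist activity at melanin-concentrating hormone receptor 1 (Homo sapiens), read by cAMP accumulation (a lower number here means that less compound is needed, a higher number that more compound is needed for the effect), 69 nM
Compound 2 `COC(=O)Nc1ccc2c(c1)C[C@@H](CN1CC[C@@H](n3c(C)nc4cc(C)ccc43)[C@H](OC)C1)C2`: 20 nM

Compound 2 gives the lowest of the two numbers; compound 1 lies a 3.5-fold lower number from compound 1 to compound 2 (0.54 log units; beyond the scatter) away. Compound 3 `CO[C@@H]1CN(C[C@H]2Cc3ccc(Br)cc3C2)CC[C@H]1n1c(C)nc2cc(C)ccc21` carries the change (bromo in place of (methoxycarbonyl)amino on an aromatic carbon). Within the data shown here, the one measured step bears on it only indirectly: it shows what (methoxycarbonyl)amino brought over hydrogen in compound 1, whereas here that group gives way to bromo, for which no step is known. A partial return toward the hydrogen case is expected, so for compound 3 the step is estimated at a 2.3-fold higher number from compound 2 to compound 3 (0.35 log units; beyond the scatter). Compound 3 is expected near 45 nM, within 15 nM to 140 nM.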

Compound 3, half-maximal effective concentration: 20 nM
Estimate against measurement, compound 3: 2.3-fold (0.35 log units) above; the measured number falls inside the stated range.
By their numbers in this assay, from the lowest: compounds 2 and 3 (each within the scatter of the next); then compound 1.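

At this aromatic carbon, (methoxycarbonyl)amino can give way to bromo, with 1 heavy atom and 0 hydrogen-bond donors or acceptors, with no change at the digits printed from compound 2 to compound 3 (within the scatter). Set against hydrogen, bromo gives a 3.5-fold lower number from compound 1 to compound 3 (0.54 log units; beyond the scatter), a step of the same printed size as a 3.5-fold lower number from compound 1 to compound 2 (0.54 log units; beyond the scatter). No evidence on hand accounts for two such different groups giving the same number here.

Going by these compounds, whether an amine, a carboxylic acid or a longer chain at this carbon would stay level with compound 2 and compound 3 remains open. So does the effect of chloro or methoxy there.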